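From Trifluoromethyl to Fluoro: Little Change Expected

A few compounds are considered here, and "the series" means these few. Any claim that something is new, unique, unknown or untested is made for them only; others in the source may bear on it.

Among the compounds with values here, in a functional assay on BT-483 cells (Homo sapiens) for cytotoxicity, read by MTT assay, with a stated time of 24 h (a higher number here means a weaker inhibitor, a lower number a stronger inhibitor), compound 1 `CCNc1cc(-c2ccc(NC(=O)Nc3cccc(Cl)c3)cc2C)ccn1` gives 16600 nM and compound 2 `CCNc1cc(-c2ccc(NC(=O)Nc3cccc(Cl)c3)cc2C(F)(F)F)ccn1` gives 13300 nM, so compound 2 stands level with the only other measured compound. Compound 3 `CCNc1cc(-c2ccc(NC(=O)Nc3cccc(Cl)c3)cc2F)ccn1` has fluoro in place of trifluoromethyl on an aromatic carbon. Within the data shown here, one measured step bears on this change, the swap of methyl for trifluoromethyl on the same carbon, and it is small: a 1.2-fold lower number from compound 1 to compound 2 (0.10 log units; within the scatter). A single step is thin evidence, and fluoro itself has not been measured at this carbon. Even so, nothing measured so far points to a large shift in this assay, so no change beyond the scatter is expected. The expected step is a 1.1-fold higher number from compound 2 to compound 3 (0.05 log units; within the scatter). The estimated value for compound 3 is 15000 nM, within an expected range of 7000 nM to 30000 nM.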

Compound 3, half-maximal inhibitory concentration: 18500 nM
Estimate against measurement, compound 3: 1.2-fold (0.09 log units) below; measured number inside the range.
By their numbers in this assay, from the lowest: compounds 2, 1 and 3 (each within the scatter of the next).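

Fluoro completes a set of three groups on this carbon, and the group can now shrink from the four heavy atoms of trifluoromethyl to a single atom. In this assay this gives a 1.4-fold higher number from compound 2 to compound 3 (0.14 log units; within the scatter), and the swap from methyl gives a 1.1-fold higher number from compound 1 to compound 3 (0.05 log units; within the scatter). The earlier pair could not show that a one-atom group would also stay within the scatter, but no group shown here separates from the others, and nothing measured here says what lies behind this flat picture.

Going by these compounds, whether an amine, a carboxylic acid or a longer chain such as propyl on this carbon would move the number beyond the scatter remains open. These compounds also vary only this one carbon, so they cannot say whether changes elsewhere on the shared core would matter more.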